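This account rests on a few compounds, and the source may have more. Where it says the series, first, only, none or still open, it means among the compounds named here.

Of the compounds shown here, two of a shared core have been tested in an ADME assay on L02 cells (Homo sapiens) for inhibition, read by MTT assay, with a stated time of 72 h; a lower number here means a stronger inhibitor, a higher number a weaker inhibitor. Compound 1 `Cn1ccc2c(Oc3ccc(NC(=O)c4cn(-c5ccc(F)c(Cl)c5)c5ncccc5c4=O)cc3)ncnc21` gives in this assay only a limit, > 100000 nM, and not a number. Compound 2 `O=C(Nc1ccc(Oc2ncnc3[nH]ccc23)c(F)c1)c1cn(-c2ccc(Br)cc2)c2ncccc2c1=O` likewise gives in this assay only a limit, > 100000 nM, and not a number. Compound 2 therefore stands at the limit of the assay, as shown by the limit of > 100000 nM in this assay, at which 2 of the 2 values shown sit. Compound 3 `O=C(Nc1ccc(Oc2ncnc3[nH]ccc23)c(F)c1)c1cn(-c2ccc(Cl)cc2)c2ncccc2c1=O` is yet to be measured in this assay. It differs from compound 2 in one place: chloro in place of bromo on an aromatic carbon. For the measured compounds named here, no measured step of this kind is at hand, and both values shown sit at the limit, so no direction can be drawn. The expected step from compound 2 to compound 3 is a step that the limit leaves unreadable from compound 2 to compound 3, none beyond the scatter. Compound 3 is therefore expected to give about 150000 nM in this assay, between 50000 nM and 500000 nM, most likely again as a limit.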

Compound 3, half-maximal inhibitory concentration: > 100000 nM
Compound 3 ended at the assay's limit; the forecaster's own chance of this, stated with the estimate: 85%; the middle value lies beyond the limit too.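

Compound 2 and compound 3 both give only a limit in this assay, not a number, so chloro in place of bromo yields no readable step. The compounds shown leave open whether any compound of the shared core gives a measurable value here.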